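This account rests on a few compounds, and the source may have more. Where it says the series, first, only, none or still open, it means among the compounds named here.

Measured so far:
- compound 1 `C/C=C/COc1noc2c1CNCC2`: 7.7
- compound 2 `CC#CCOc1noc2c1CNCC2`: 7.6
- compound 3 `CCCCOc1noc2c1CNCC2`: 7.6

The three compounds share a core and differ only in the chain on its oxygen. In a physicochemical assay for acid dissociation, compound 3 gives 7.6, the same figure as compound 2 at the digits shown and within the scatter of compound 1.

The next compound is compound 4 `CC(C)Oc1noc2c1CNCC2`, which carries isopropyl in place of butyl on an oxygen on an aromatic ring.

Going by the values given here, three measured steps bear on this change, though only indirectly. Replacing prop-1-en-1-yl with prop-1-yn-1-yl gave a number 0.10 log units lower from compound 1 to compound 2 (within the scatter). Replacing prop-1-en-1-yl with propyl gave a number 0.10 log units lower from compound 1 to compound 3 (within the scatter). Replacing prop-1-yn-1-yl with propyl gave no change at the digits printed from compound 2 to compound 3 (within the scatter).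

None of these steps goes beyond the scatter, so the chain variations tried so far have left the number in this assay essentially unmoved. Among the compounds with values here, all of them, however, keep the same saturated chain carbon bound to the oxygen, and no measured compound has isopropyl on that oxygen. The comparison is therefore an extrapolation.

The expected change is no change at the digits printed from compound 3 to compound 4 (within the scatter), which would be no step beyond the scatter. For compound 4 the estimated value is 7.6, with an expected range from 7.3 to 7.9.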

Compound 4, acid dissociation constant: 7.5
Beside the measured number, compound 4's estimate is 0.10 log units above it; the measured number falls inside the stated range.
By their numbers in this assay, from the lowest: compounds 4, 2, 3 and 1 (each within the scatter of the next).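

Going by these compounds alone, compound 4 is the first in this set to change the carbon bound to the oxygen on an aromatic ring, and in this assay the switch to isopropyl leaves the number within the scatter of its closest relatives (a number 0.10 log units lower from compound 3 to compound 4 (within the scatter); a number 0.10 log units lower from compound 2 to compound 4 (within the scatter)). The same holds against the but-2-en-1-yl group of compound 1 (a number 0.20 log units lower from compound 1 to compound 4 (within the scatter)), so no step among these four compounds goes beyond the scatter, and the change at this carbon has moved the number no more clearly than the earlier chain variations did. Nothing among the data offers an explanation for this flat result.

The compounds shown carry only small hydrocarbon groups on this oxygen, so they leave open whether the number in this assay would stay level with a longer chain, a cyclohexyl or phenyl ring, or a chain ending in an amine or a carboxylic acid. They also leave open what a change elsewhere on the shared core would do, since all four compounds differ only in the group on this oxygen.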